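The source may hold more compounds than are shown below. What is called first, only, known or untested is meant among the compounds shown, and "the series" means these compounds.

Measured so far:
compound 1 `CC(C)(C)OC(=O)/C=C1/C(=O)Nc2ccccc21`: 87.6%
compound 2 `CN1C(=O)/C(=C/C(=O)OC(C)(C)C)c2ccccc21`: 86.6%
compound 3 `Cc1ccc2c(c1)/C(=C\C(=O)OC(C)(C)C)C(=O)N2`: 87.8%

All three were read in a functional assay on MDA-MB-231 cells (Homo sapiens) for inhibition, read by CCK-8 assay, with a stated time of 72 h, tested at 20 uM; a higher number here means more inhibition of growth at the concentration tested, a lower number less inhibition of growth. Compound 1 sits in a tight band with compounds 2 and 3: the step of a number 1 percentage points lower from compound 1 to compound 2 (within the scatter) and the step of a number 0.2 percentage points higher from compound 1 to compound 3 (within the scatter) are both within the scatter, so the three numbers cannot be told apart.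

Compound 4 `COc1ccc2c(c1)/C(=C\C(=O)OC(C)(C)C)C(=O)N2` differs from compound 1 by methoxy in place of hydrogen on an aromatic carbon. The step that bears most directly on this change is the methyl on an aromatic carbon, a number 0.2 percentage points higher from compound 1 to compound 3 (within the scatter), which left the read-out unchanged. The methyl on the ring nitrogen, a number 1 percentage points lower from compound 1 to compound 2 (within the scatter), touches a different part of the core but also stayed within the scatter. Nothing in the series has yet moved this assay beyond its scatter, so for compound 4 no step beyond the scatter is expected in either direction, a number 1.6 percentage points lower from compound 1 to compound 4 (within the scatter). Compound 4 is therefore estimated at 86%, with a range from 77% to 93%.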

Compound 4, percent growth inhibition at one concentration: 87.6%
Compound 4: middle estimate off by 1.6 percentage points, on the low side, and the stated range covers the measured number.
By their numbers in this assay, from the lowest: compounds 2, 1, 4 and 3 (each within the scatter of the next).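

In this assay, methoxy on this aromatic carbon, para to a fused ring, gives no change at the digits printed from compound 1 to compound 4 (within the scatter) and so leaves the read-out level with the unsubstituted compound. Compound 3 carries methyl on the same carbon, and the swap to methoxy gives a number 0.2 percentage points lower from compound 3 to compound 4 (within the scatter), so this position now has two different substituents behind it rather than methyl alone, and neither step lies beyond the scatter. Nothing available explains why the read-out holds across these changes.

As far as these compounds go, it stays open whether an amine, a carboxylic acid or a longer alkoxy chain on this carbon would move the read-out beyond the scatter. The compounds shown also all keep the tert-butyl ester, so the effect of changing that part of the structure remains unknown.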